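The source may hold more compounds than are shown below. What is called first, only, known or untested is meant among the compounds shown, and "the series" means these compounds.

Measured so far:
compound 1, `O=C(O)CCC[C@H](O)[C@@H](/C=C\c1ccc(OCCCCOc2ccccc2)cc1)Sc1ccc(C(=O)O)cc1`, gives 6.5 in a functional assay on trachea for antagonist activity at cysteinyl leukotriene receptor 1 (Cavia porcellus); on this read-out lower numbers stand for lower potency and higher numbers for higher potency (the scale is a negative logarithm)
compound 2, `O=C(O)CCC[C@H](O)[C@@H](/C=C\c1cccc(OCCCCOc2ccccc2)c1)Sc1ccc(C(=O)O)cc1`, gives < 5 in this assay

For compound 2 the result in this assay is a limit of the assay rather than a number, as shown by the limit of < 5 in this assay, at which 1 of the 2 values shown sits. Compound 3, `O=C(O)CCC[C@H](O)[C@@H](/C=C/c1cccc(OCCCCOc2ccccc2)c1)Sc1ccc(C(=O)O)cc1`, keeps every atom and bond of compound 2: the two compounds have the same atoms and bonds and differ only in configuration as drawn: 1 of 3 stereo elements differ; a double bond is drawn Z in compound 2 and E in compound 3. Within the data shown here, with no measured pair of this kind to lean on, the change in this assay from compound 2 to compound 3 is expected to be small, likely within the scatter, at a number at least 0.20 log units higher from compound 2 to compound 3 (that floor lies within the scatter). Compound 3 is therefore estimated at 5.2, between 4.5 and 6.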

Compound 3, negative logarithm of the antagonist equilibrium constant: 6.8
For compound 3 the middle estimate is 1.60 log units below the measured one; measured number above the stated range.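

In this assay compound 2 gives < 5, which is a limit of the assay and not a number. Even so, the step can be read as a number at least 1.80 log units higher from compound 2 to compound 3 (beyond the scatter), so at this double bond the geometry alone, Z or E, separates a compound with no measured number from one with clear potency. Nothing else differs, and this is the first sign of how much this one feature counts: the fact that compounds 2 and 3 differ only in the configuration as drawn

Going by these compounds, whether the switch from Z to E acts the same way in compound 1 stays open. So does the effect of a tetrazole in place of either carboxylic acid.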